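Swapping Cyclohexyl for Isobutyl in a Sulfonamide Series

The compounds below may be only part of what the source reports. "The series", "measured", "known", "first", "only" and "open" are said of these compounds alone.

Compound 1 `O=C1NCCN1c1ccc(S(=O)(=O)Nc2ccc(C3CCCCC3)cc2)cc1` was tested in a functional assay on HT-29 cells (Homo sapiens) for antiproliferative activity, read by sulforhodamine B assay, with a stated time of 48 h; a higher number here means a weaker inhibitor, a lower number a stronger inhibitor. In this assay compound 1 gives only a limit of the assay, > 1000 nM, and not a number. Compound 2 `CC(C)(C)c1cc(NS(=O)(=O)c2ccc(N3CCNC3=O)cc2)cc(C(C)(C)C)c1` likewise returns a limit in this assay, > 1000 nM. Among the measured compounds shown here, both values sit at the same point, as the limit of > 1000 nM in this assay, at which 2 of the 2 values shown sit, shows, so compound 1 stands level with the only other compound measured. Compound 3 `CC(C)Cc1ccc(NS(=O)(=O)c2ccc(N3CCNC3=O)cc2)cc1` differs from compound 1 by isobutyl in place of cyclohexyl on an aromatic carbon. For the measured compounds named here, no measured step covers this change, so the step that the limit leaves unreadable from compound 1 to compound 3 is expected to be none beyond the scatter. Compound 3 is estimated at 3000 nM, between 800 nM and 20000 nM.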

Compound 3, half-maximal inhibitory concentration: > 1000 nM
Compound 3 was reported as a limit; the forecaster's own chance of this, stated with the estimate: 75%; the middle value is on the limit's open side.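

Among the compounds shown here, no step from compound 1 to compound 3 can be read, since each gives only a limit and not a number: the limit of > 1000 nM in this assay, at which 3 of the 3 values shown sit. The compounds shown leave open how strongly each acts and whether isobutyl or cyclohexyl gives the stronger inhibitor.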